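The source may hold more compounds than are shown below. What is called first, only, known or untested is meant among the compounds shown, and "the series" means these compounds.

The set shares one core, carried by three measured compounds and one that has not yet been tested. Compound 1 `O=C(Nc1cc(C(F)(F)F)cc(C(F)(F)F)c1)C1CCc2ccccc2N1C(=O)c1ccccc1Cl` gives 4050 nM in a functional assay on HCT-15 cells (Homo sapiens) for cytotoxicity, read by sulforhodamine B assay, with a stated time of 72 h; a higher number here means a weaker inhibitor of growth, a lower number a stronger inhibitor of growth. Compound 2 `CC(=O)N1c2ccccc2CCC1C(=O)Nc1cc(C(F)(F)F)cc(C(F)(F)F)c1` reaches only the limit of this assay, > 70000 nM, so no number is known for it. Compound 3 `CCCCCCCCC(=O)N1c2ccccc2CCC1C(=O)Nc1ccccc1C(F)(F)F` gives 7700 nM, which is the highest of the two numbers shown, with compound 1 the nearest to it and within the scatter.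

The step under consideration leads from compound 3 to compound 4 `CCC(=O)N1c2ccccc2CCC1C(=O)Nc1ccccc1C(F)(F)F`: hydrogen in place of hexyl on a saturated chain carbon, two bonds along the chain from a carbonyl carbon. Among the measured compounds shown here, only one measured step changes the acyl group on the amide nitrogen, and that is an at least 17-fold higher number from compound 1 to compound 2 (1.23 log units; beyond the scatter), which ends at the limit of > 70000 nM in this assay, at which 1 of the 3 values shown sits, rather than at a number. That step shortens the acyl group to its smallest form and loses activity; the step from compound 3 to compound 4 also shortens the acyl group, though not as far. A sizeable rise in this assay is therefore expected, though the data do not fix its size. Compound 4 is estimated at 30000 nM, within 9000 nM to 70000 nM, meaning an expected step of a 3.9-fold higher number from compound 3 to compound 4 (0.59 log units; beyond the scatter), with a fair chance that only a limit is reported.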

Compound 4, concentration for 50% growth inhibition: > 80000 nM
Compound 4 was reported as a limit (the forecaster's own chance of this, stated with the estimate: 35%); middle value at least 2.6-fold (0.42 log units) from the limit.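

In this assay, the change from octylcarbonyl to propanoyl gives an at least 10-fold higher number from compound 3 to compound 4 (1.01 log units; beyond the scatter), so a large loss of growth inhibition now appears on shortening a saturated chain, with the chain still present on the carbonyl carbon. The earlier step, an at least 17-fold higher number from compound 1 to compound 2 (1.23 log units; beyond the scatter), replaced an aromatic 2-chlorophenyl group with methyl and was made with a different group on the other amide, so it could not show that a chain of this kind matters in the same way. The true size of the new step stays unknown because compound 4 stands at a limit of the assay, not at a number: the limit of > 80000 nM in this assay, at which 1 of the 4 values shown sits.

The compounds shown leave open how the number changes with chains of intermediate length, such as butanoyl or hexanoyl, and whether a chain longer than octylcarbonyl would lower it further or raise it. They also leave open whether a 2-chlorophenyl group on the carbonyl carbon would keep its activity with the other amide of compound 3, and whether an amine or a carboxylic acid at the end of the octyl chain would be tolerated.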